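The compounds below may be only part of what the source reports. "The series", "measured", "known", "first", "only" and "open" are said of these compounds alone.

Measured so far in a functional assay on SQ20B cells (Homo sapiens) for cytotoxicity, read by MTT assay, with a stated time of 72 h; a lower number here means a stronger inhibitor, a higher number a weaker inhibitor:
- compound 1, `Oc1ccc2oc(Cc3ccccc3)cc2c1CN1CCC(N2CCCCC2)CC1`: 3000 nM
- compound 2, `Oc1ccc2oc(Cc3ccccc3)cc2c1CN1CCC(N2CCCC2)CC1`: 3000 nM

Compound 1 stands level with compound 2 in this assay: the step of no change at the digits printed from compound 1 to compound 2 (within the scatter), which exchanges one saturated ring on a saturated ring carbon for another, leaves the read-out unchanged within the scatter.

Compound 3, `O=C(NCCOCCO)C1CCN(C2CCN(Cc3c(O)ccc4oc(Cc5ccccc5)cc34)CC2)CC1`, keeps the core of compound 1 and differs in one place: (2-(2-hydroxyethoxy)ethyl)carbamoyl in place of hydrogen on a saturated ring carbon. Within the data shown here, no measured step covers a change of this kind. Among the measured compounds shown here, the only step available, from compound 1 to compound 2, concerns a different position and a different sort of substitution, and it is flat. The shared core therefore gives no sign of where a large added group would move the value.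

On that basis compound 3 is expected to sit near compound 1, with the step of a 1.3-fold higher number from compound 1 to compound 3 (0.12 log units; within the scatter) treated as small and the range kept wide. The estimate for compound 3 is 4000 nM, between 1300 nM and 12000 nM.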

Compound 3, half-maximal inhibitory concentration: 14000 nM
Compound 3: middle estimate off by 3.5-fold (0.54 log units), on the low side; the whole stated range lies below it.
By their numbers in this assay, from the lowest: compounds 1 and 2 (each within the scatter of the next); then compound 3.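

In this assay the saturated ring carbon three ring bonds from the ring nitrogen responds to substitution: (2-(2-hydroxyethoxy)ethyl)carbamoyl in place of hydrogen gives a 4.7-fold higher number from compound 1 to compound 3 (0.67 log units; beyond the scatter) and so moves the value beyond the scatter. The earlier step, no change at the digits printed from compound 1 to compound 2 (within the scatter) with one saturated ring exchanged for another, showed no such movement, and it left open whether the value could shift at all through changes on this part of the molecule. The direction of this change is upward, towards a weaker inhibitor, and nothing available here accounts for it.

As far as these compounds go, it remains open whether the rise follows the carbamoyl link itself or the hydroxyethoxy chain it carries. A plain primary carboxamide, a carboxylic acid or a simple amine on the same carbon would separate these two readings, and a longer chain would show whether the number keeps rising with length.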